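A few compounds are considered here, and "the series" means these few. Any claim that something is new, unique, unknown or untested is made for them only; others in the source may bear on it.

Three compounds have been tested in an ADME assay on Vero 76 cells (Chlorocebus sabaeus) for cytotoxicity, read by microscopy; on this read-out higher numbers stand for lower toxicity in this test and lower numbers for higher toxicity in this test:

compound 1 `CC(C)(O)[C@@H](Nc1nc(Cl)nc2c1ccn2[C@H]1[C@H](O)[C@H](O)[C@]2(CO)C[C@H]12)C1CC1`: > 100000 nM, a limit of the test rather than a number
compound 2 `OC[C@@]12C[C@@H]1[C@@H](n1ccc3c(NC(C4CCC4)C4CCC4)nc(Cl)nc31)[C@H](O)[C@@H]2O`: > 100000 nM, also a limit
compound 3 `OC[C@@]12C[C@@H]1[C@@H](n1cnc3c(NC(C4CCC4)C4CCC4)nc(Cl)nc31)[C@H](O)[C@@H]2O`: 50000 nM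

Compound 1 and compound 2 share one core, and the change between them is 1-cyclopropyl-2-hydroxy-2-methylpropyl in place of dicyclobutylmethyl on a nitrogen on an aromatic ring. The step that the two limits leave unreadable from compound 2 to compound 1 cannot be sized because both compounds sit at the limit of > 100000 nM in this assay, at which 2 of the 3 values shown sit. Compound 3 carries a different core; how the two cores differ is not broken down here. Within the data shown here, its value is the only plain number in this set.

Compound 4 `CC(C)(O)[C@@H](Nc1nc(Cl)nc2c1ncn2[C@H]1[C@H](O)[C@H](O)[C@]2(CO)C[C@H]12)C1CC1` has not yet been measured. It differs from compound 3 by 1-cyclopropyl-2-hydroxy-2-methylpropyl in place of dicyclobutylmethyl on a nitrogen on an aromatic ring, the same change that turns compound 2 into compound 1, at the same place. That earlier step gives no measured size to carry over. The expectation for compound 4 is a small step of a 1.6-fold higher number from compound 3 to compound 4 (0.20 log units; within the scatter). This expectation rests on compound 3 at 50000 nM. The two limits of compound 1 and compound 2 add no measured size to it. Compound 4 is expected at about 80000 nM, within 30000 nM to 200000 nM.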

Compound 4, half-maximal cytotoxic concentration: > 100000 nM
Compound 4 was reported as a limit; the forecaster's own chance of this, stated with the estimate: 60%; middle value at least 1.2-fold (0.09 log units) away from the limit.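

On the core of compound 3, putting 1-cyclopropyl-2-hydroxy-2-methylpropyl in place of dicyclobutylmethyl gives, in this assay, an at least 2.0-fold higher number from compound 3 to compound 4 (0.30 log units; that floor lies within the scatter). That is a floor and not a size: compound 4 is reported only as a limit, so the real step could be larger or could stay within the usual scatter. The same change on the other core, from compound 2 to compound 1, cannot be read, so nothing shows whether the step has the same size on both cores, and the test's ceiling hides most of the picture: the limit of > 100000 nM in this assay, at which 3 of the 4 values shown sit.

Still open, on these data alone, is whether another group on a nitrogen on an aromatic ring, such as a carboxylic acid or a chain ending in an amine, would bring the number down into the range the test can read. Only a pair with plain numbers on both cores could show whether a change carries over from one core to the other in size.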